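Working notes: from compound 3 to compound 4

The source may hold more compounds than are shown below. What is called first, only, known or untested is meant among the compounds shown, and "the series" means these compounds.

Measured in a functional assay on K562 cells (Homo sapiens) for cytotoxicity, read by MTT assay, with a stated time of 24 h; a higher number here means a weaker inhibitor, a lower number a stronger inhibitor:
- compound 1 `CN1C/C(=C\c2cccc([N+](=O)[O-])c2)C(=O)/C(=C/c2ccccc2F)C1`: 3890 nM
- compound 2 `COc1cc(/C=C2\CN(C)C/C(=C\c3ccc(F)cc3)C2=O)cc(OC)c1`: 11300 nM
- compound 3 `COc1cc(/C=C2\CN(C)C/C(=C\c3ccc(F)cc3)C2=O)cc(OC)c1OC`: 10300 nM

Compound 3 sits within the scatter of compound 2, and compound 1 lies lower than both, beyond the scatter. Compound 4 `COc1cc(/C=C2\CN(C)C/C(=C\c3ccc(Cl)c(Cl)c3)C2=O)cc(OC)c1OC` carries 3,4-dichlorophenyl in place of 4-fluorophenyl on a double-bonded chain carbon bound to a double-bonded ring carbon. Among the measured compounds shown here, the only measured step, a 1.1-fold lower number from compound 2 to compound 3 (0.04 log units; within the scatter), is a methoxy in place of hydrogen at a different place and lies within the scatter, so it bears only indirectly. Compound 1, at 3890 nM, differs in more than one place and merely shows that lower numbers occur in this series. A step within the scatter, leaning lower, is therefore expected in this assay: the estimate is a 1.7-fold lower number from compound 3 to compound 4 (0.23 log units; within the scatter). For compound 4 the expected value is 6000 nM, with an estimated range of 2000 nM to 14000 nM.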

Compound 4, half-maximal inhibitory concentration: 16200 nM
Estimate against measurement, compound 4: 2.7-fold (0.43 log units) below; measured number above the stated range.
By their numbers in this assay, from the lowest: compound 1; then compounds 3, 2 and 4 (each within the scatter of the next).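

In this assay, 3,4-dichlorophenyl in place of 4-fluorophenyl on a double-bonded chain carbon bound to a double-bonded ring carbon gives a 1.6-fold higher number from compound 3 to compound 4 (0.20 log units; within the scatter). This place therefore accepts this exchange of aryl groups without a change beyond the scatter, as the methoxy step at a different place did with a 1.1-fold lower number from compound 2 to compound 3 (0.04 log units; within the scatter). No measured property bears on this step.

Still open, going by these compounds, is whether an aminophenyl or a carboxyphenyl group at this place would move the number beyond the scatter. Also open, on these data alone, is which of the differences in compound 1 goes with its 3890 nM.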